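Removing One Chloro from Compound 3

The source may hold more compounds than are shown below. What is called first, only, known or untested is meant among the compounds shown, and "the series" means these compounds.

In a functional assay on U-87MG ATCC cells for antiproliferative activity against U-87 MG (Homo sapiens), read by MTT assay, with a stated time of 48 h, tested at 5 uM (on this read-out lower numbers stand for a stronger effect and higher numbers for a weaker effect at the one concentration tested), compound 3 `Cc1nc(-c2ccc(Cl)cc2)sc1C(=O)CSc1nc(-c2ccc(Cl)c(Cl)c2)c(C#N)c(=O)[nH]1` gives 101%, the highest of the three numbers shown, a weaker effect than either companion. Compound 2 `Cc1nc(-c2ccc(Cl)cc2)sc1C(=O)CSc1nc(-c2ccccc2)c(C#N)c(=O)[nH]1` gives 88.9%, and compound 1 `COc1ccc(-c2nc(SCC(=O)c3sc(-c4ccccc4)nc3C)nc(N)c2C#N)cc1` gives 68.8%. Among the compounds with values here, the one measured step that bears on the next change is a number 12.1 percentage points higher from compound 2 to compound 3 (beyond the scatter), a shift beyond the scatter. Compound 4 `Cc1nc(-c2ccc(Cl)cc2)sc1C(=O)CSc1nc(-c2cccc(Cl)c2)c(C#N)c(=O)[nH]1` differs from compound 3 by hydrogen in place of chloro on an aromatic carbon, which undoes part of that earlier change. Because of a number 12.1 percentage points higher from compound 2 to compound 3 (beyond the scatter), compound 4 is expected to show a step of a number 6 percentage points lower from compound 3 to compound 4 (within the scatter) that is small and downward, quite possibly within the scatter. In this assay compound 4 is expected to give 95%, within a range from 80% to 108%.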

Compound 4, a percentage reported as activity, at one concentration (the size of the read-out at that concentration, not a potency): 80.2%
Compound 4: middle estimate off by 14.8 percentage points, on the high side, within the range that was stated.
By their numbers in this assay, from the lowest: compound 1; then compounds 4 and 2 (each within the scatter of the next); then compound 3.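

In this assay the change to hydrogen gives a number 20.8 percentage points lower from compound 3 to compound 4 (beyond the scatter) and so is beyond the scatter on its own. The other pair reads a number 8.7 percentage points lower from compound 2 to compound 4 (within the scatter) and stays within the scatter, so among these compounds the higher number goes with 3,4-dichlorophenyl, not with 3-chlorophenyl. Nothing available explains this result.

From the compounds shown here alone, whether only chloro gives this rise on the carbon para to a large group stays open. An amine or a carboxylic acid there could give a different number.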